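The compounds below may be only part of what the source reports. "The series", "measured", "known", "first", "only" and "open" are said of these compounds alone.

Of the compounds shown here, three from this series have been tested in a functional assay on MCF7 cells (Homo sapiens) for inhibition, read by sulforhodamine B assay, with a stated time of 72 h (a higher number here means a weaker inhibitor of growth, a lower number a stronger inhibitor of growth), and two of them reach only a limit of the assay. Compound 1, `NC(=O)/C=C/c1ccncc1-c1ccc2ccccc2c1`, gives > 10000 nM in this assay, which is a limit and not a number. Compound 2, `Cn1ccc2cc(-c3cnccc3/C=C/C(=O)O)ccc21`, likewise gives > 10000 nM in this assay, again a limit. Among the compounds with values here, compound 3, `CNC(=O)/C=C/c1ccncc1-c1ccc2cc[nH]c2c1`, is the one member with a number, giving 9230 nM in this assay. Compound 1 therefore stands at the weak end of what has been measured, with no number of its own, and the limit of > 10000 nM in this assay, at which 2 of the 3 values shown sit, describes where it lies.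

Compound 4, `CCOC(=O)/C=C/c1ccncc1-c1ccc2ccccc2c1`, is the next analogue to be measured. It differs from compound 1 by ethoxy in place of amino on a carbonyl carbon, so that the carbamoyl group of compound 1 becomes an ethoxycarbonyl group. Within the data shown here, no measured pair in the set carries this change, so its size can only be estimated. Given that compound 1 and compound 2 sit at the limit and compound 3 lies near it, the step of a number no higher from compound 1 to compound 4 (the limit leaves the size open) is expected to be small, with no clear direction beyond the scatter. Compound 4 is thus expected to give about 10000 nM in this assay, within a range from 4000 nM to 30000 nM.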

Compound 4, concentration for 50% growth inhibition: 8320 nM
For compound 4 the middle estimate is 1.2-fold (0.08 log units) above the measured one; the measured number falls inside the stated range.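

With ethoxy in place of amino on the carbonyl carbon, the carbamoyl group of compound 1 becomes the ethoxycarbonyl group of compound 4, and this assay gives an at least 1.2-fold lower number from compound 1 to compound 4 (0.07 log units; that floor lies within the scatter). This is the first pair shown that differs in one place, and it shows that this position can carry an ester while the value stays in the same part of the scale, with compound 4 at 8320 nM. It does not show a real gain from the change, and the true size of the step stays open because compound 1 has only a limit and no number of its own: the limit of > 10000 nM in this assay, at which 2 of the 4 values shown sit.

The compounds shown leave open how a methoxy group, a longer alkoxy chain or a dimethylamino group on this carbonyl carbon would read against the ethoxy group of compound 4. They also leave open whether ethoxy in place of the amide nitrogen group would read the same on the core of compound 3, which is the only other amide with a number.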